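Sulfonamide series notes: step from compound 3 to compound 4

The source may report more compounds than this note shows. Statements on the series, on what has been measured and on what is new or still open speak of the compounds shown alone.

Values in a functional assay on A2780 cells (Homo sapiens) for inhibition, read by MTT assay, with a stated time of 72 h; a higher number here means a weaker inhibitor of growth, a lower number a stronger inhibitor of growth:
compound 1, `O=S(=O)(NCCCNCc1ccccc1Cl)c1cc(C(F)(F)F)cc(C(F)(F)F)c1`, 9300 nM
compound 2, `O=S(=O)(NCCCCNCc1ccc(Br)cc1)c1cc(C(F)(F)F)cc(C(F)(F)F)c1`, 2100 nM
compound 3, `O=S(=O)(NCCCNCc1ccc(Cl)c(Cl)c1)c1cc(C(F)(F)F)cc(C(F)(F)F)c1`, 1500 nM

Compound 3 has the lowest number of the three. Its gap to compound 2 is within the scatter (a 1.4-fold lower number from compound 2 to compound 3 (0.15 log units; within the scatter)), so the two cannot be ordered; its gap to compound 1 is beyond the scatter (a 6.2-fold lower number from compound 1 to compound 3 (0.79 log units; beyond the scatter)), as is the gap from compound 1 to compound 2 (a 4.4-fold lower number from compound 1 to compound 2 (0.65 log units; beyond the scatter)). All three measured steps exchange one halogenated phenyl for another on the same benzylic position, and none is larger than modest.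

Compound 4, `O=S(=O)(NCCCNCC1COc2ccccc2O1)c1cc(C(F)(F)F)cc(C(F)(F)F)c1`, differs from compound 3 by 2,3-dihydro-1,4-benzodioxin-2-yl in place of 3,4-dichlorophenyl on a saturated chain carbon bound to an amine nitrogen. Going by the values given here, no measured step bears directly on this change: every measured compound carries a halogenated phenyl, and none carries a ring with oxygen in it. Among the compounds with values here, the only guidance is that changing the group at this position has moved the number by modest amounts in either direction. Loss of both chlorines, which in the measured set accompany the lowest numbers, is taken to point toward a higher number, so a modest step upward is expected, a 3.3-fold higher number from compound 3 to compound 4 (0.52 log units; beyond the scatter), with wide uncertainty. Compound 4 is therefore estimated at 5000 nM in this assay, in the range 1500 nM to 20000 nM.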

Compound 4, concentration for 50% growth inhibition: 1500 nM
Compound 4: middle estimate off by 3.3-fold (0.52 log units), on the high side, and the stated range covers the measured number.
By their numbers in this assay, from the lowest: compounds 3, 4 and 2 (each within the scatter of the next); then compound 1.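

In this assay, going by these compounds alone, the step from a halogenated phenyl to a group without halogen gives no change at the digits printed from compound 3 to compound 4 (within the scatter), so at this position, on a saturated chain carbon bound to an amine nitrogen, chlorine on a phenyl is not needed for a number at the low end of the set, which the earlier compounds, all halogenated, could not show. The same group set against 2-chlorophenyl gives a 6.2-fold lower number from compound 1 to compound 4 (0.79 log units; beyond the scatter), so the high number of compound 1 is not shared by every group tried here, and this position accepts a ring with oxygen in it and a larger group of 10 heavy atoms without a step beyond the scatter from compound 3. Nothing available accounts for the match between the 3,4-dichlorophenyl and 2,3-dihydro-1,4-benzodioxin-2-yl compounds.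

Open, from the compounds shown here alone, is whether an unsubstituted phenyl or a 1,2,3,4-tetrahydronaphthalen-2-yl group would give a similar number, which would separate the part played by the ring oxygens from the loss of chlorine. Also open, going by these compounds, is how the 2,3-dihydro-1,4-benzodioxin-2-yl group behaves on a longer chain.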